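From an aminophenyl to a dimethoxyphenyl ketone

This account rests on a few compounds, and the source may have more. Where it says the series, first, only, none or still open, it means among the compounds named here.

Three measured compounds share a core in which an enone links a pyrazole to an aryl ketone. Compound 1, `COc1ccc(-c2cc(/C=C/C(=O)c3ccc(N)cc3)[nH]n2)cc1`, gives 56200 nM in a functional assay on SW-620 cells (Homo sapiens) for inhibition, read by sulforhodamine B assay, with a stated time of 48 h; a lower number here means that less compound is tolerated, a higher number that more compound is tolerated. Compound 2, `COc1cc(-c2cc(/C=C/C(=O)c3ccc(N)cc3)[nH]n2)cc(OC)c1OC`, reaches only a limit of this assay, namely > 100000 nM. Compound 3, `COc1cc(-c2cc(/C=C/C(=O)c3ccc(Cl)c(Cl)c3)[nH]n2)cc(OC)c1OC`, also reaches only a limit in this assay, namely > 100000 nM. The step that the two limits leave unreadable from compound 2 to compound 3 cannot be sized because both of its values sit at the limit of > 100000 nM in this assay, at which 2 of the 3 values shown sit.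

Compound 2 therefore stands at the tolerated end of the numbers shown, with only a limit to its name; compound 1 stands at a readable value, and no step between the two is given.

Compound 4, `COc1ccc(C(=O)/C=C/c2cc(-c3cc(OC)c(OC)c(OC)c3)n[nH]2)cc1OC`, differs from compound 2 as follows: 3,4-dimethoxyphenyl in place of 4-aminophenyl on a carbonyl carbon. Within the data shown here, the only measured step that exchanges the 4-aminophenyl on the carbonyl carbon is the one from compound 2 to compound 3, and that step is unreadable, so no measured step sets the size to expect in this assay. The account is thus left with the position of compound 2 alone.

Compound 4 is expected to give about 90000 nM, with a range from 30000 nM to 300000 nM. The step of an at least 1.1-fold lower number from compound 2 to compound 4 (0.04 log units; that floor lies within the scatter) is expected to be small, within the scatter.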

Compound 4, concentration lethal to 50% of the cells: 6550 nM
Compound 4: middle estimate off by 14-fold (1.14 log units), on the high side; the whole stated range lies above it.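

The exchange on the carbonyl carbon now has a readable direction in this assay. Setting 3,4-dimethoxyphenyl in place of 4-aminophenyl gives an at least 15-fold lower number from compound 2 to compound 4 (1.18 log units; beyond the scatter), and setting it in place of 3,4-dichlorophenyl gives an at least 15-fold lower number from compound 3 to compound 4 (1.18 log units; beyond the scatter), so the group at this place can move the read-out well beyond the scatter, which the unreadable step between the two earlier compounds could not show. Both steps are floors and not full sizes, because each starts from a compound that reaches only a limit of the assay: the limit of > 100000 nM in this assay, at which 2 of the 4 values shown sit.

The compounds shown leave open whether the gain depends on both methoxy groups of the 3,4-dimethoxyphenyl, or whether it would survive with an ethoxy group in place of each methoxy group. They also leave open how far the same exchange would move compound 1, which gives 56200 nM with its 4-aminophenyl still in place.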